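A few compounds are considered here, and "the series" means these few. Any claim that something is new, unique, unknown or untested is made for them only; others in the source may bear on it.

Measured in a functional assay on HL-60 cells (Homo sapiens) for antiproliferative activity, read by MTT assay, with a stated time of 48 h; a higher number here means a weaker inhibitor, a lower number a stronger inhibitor:
- Compound 1 `CN(C)CCCCn1c(N)c(-c2nc3ccccc3s2)c2nc(C#N)c(C#N)nc21`: 830 nM
- Compound 2 `CCN(CC)CCn1c(N)c(-c2nc3cc(Cl)ccc3[nH]2)c2nc(C#N)c(C#N)nc21`: > 50000 nM

For compound 2, the value > 50000 nM is only a limit.

Compound 3 `CN(C)CCCCn1c(N)c(-c2nc3cc(Cl)ccc3[nH]2)c2nc(C#N)c(C#N)nc21` differs from compound 2 by one change, 2-(dimethylamino)ethyl in place of diethylamino on a saturated chain carbon, two bonds along the chain from an aromatic nitrogen. A shift towards stronger inhibition is expected in this assay. This expectation rests on compound 1, which gives 830 nM. The expected size is an at least 12-fold lower number from compound 2 to compound 3 (1.09 log units; beyond the scatter). For compound 3 the estimated value is 4000 nM, with an expected range of 600 nM to 30000 nM.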

Compound 3, half-maximal inhibitory concentration: 1480 nM
Compound 3: the middle estimate sits 2.7-fold (0.43 log units) above what was measured, within the range that was stated.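

Replacing 2-(diethylamino)ethyl with 4-(dimethylamino)butyl on the shared core gives an at least 33-fold lower number from compound 2 to compound 3 (1.52 log units; beyond the scatter), showing that this side chain alone can decide the activity of the chloro-substituted series. Compound 2 stands at a limit: the limit of > 50000 nM in this assay, at which 1 of the 3 values shown sits.

With the 4-(dimethylamino)butyl chain held, 5-chloro-1H-benzimidazol-2-yl in place of 1,3-benzothiazol-2-yl gives a 1.8-fold higher number from compound 1 to compound 3 (0.25 log units; within the scatter), so these two groups are not told apart here.

The step changes chain length and the amine together, and a 2-(dimethylamino)ethyl or 4-(diethylamino)butyl chain would separate the two. Also open, on these data alone, is how a cyclic amine such as morpholine on the chain would compare.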